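Swapping a Hydroxymethyl for a Methyl-Oxadiazole Ring

The compounds below may be only part of what the source reports. "The series", "measured", "known", "first", "only" and "open" are said of these compounds alone.

Three compounds have been measured in an assay on isolated protein for inhibition of sodium-dependent dopamine transporter (Rattus norvegicus), read by radioligand binding; a higher number here means a weaker inhibitor, a lower number a stronger inhibitor:

Compound 1, `CN1CCC(c2ccc(Cl)cc2)C(C[S+]([O-])CCO)C1`, gives 12 nM.
Compound 2, `COCC[S+]([O-])CC1CN(C)CCC1c1ccc(Cl)cc1`, gives 15 nM.
Compound 3, `CNC(=O)C[S+]([O-])CC1CN(C)CCC1c1ccc(Cl)cc1`, gives 164 nM.

Compound 1 has the lowest of the three numbers; compound 2 sits within the scatter of it (a 1.3-fold higher number from compound 1 to compound 2 (0.10 log units; within the scatter)), while compound 3 lies far above it (a 14-fold higher number from compound 1 to compound 3 (1.14 log units; beyond the scatter)). Compound 4, `Cc1noc(C[S+]([O-])CC2CN(C)CCC2c2ccc(Cl)cc2)n1`, differs from compound 1 by 3-methyl-1,2,4-oxadiazol-5-yl in place of hydroxymethyl on a saturated chain carbon bound to a sulfur. Among the measured compounds shown here, two steps bear on this change. The small step from compound 1 to compound 2 shows that the hydroxyl hydrogen can go without cost; the large step from compound 1 to compound 3 shows that a bulkier group in the same place can cost a great deal. The entering ring is bulkier still and lacks a donor, so a moderate loss is expected for compound 4, a 3.8-fold higher number from compound 1 to compound 4 (0.57 log units; beyond the scatter). Compound 4 is estimated at 45 nM, with a range from 12 nM to 170 nM.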

Compound 4, inhibition constant: 1650 nM
The estimate for compound 4 lay 37-fold (1.56 log units) below the measured number; the measured number lies above the stated range.
By their numbers in this assay, from the lowest: compounds 1 and 2 (each within the scatter of the next); then compound 3; then compound 4.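

Placing 3-methyl-1,2,4-oxadiazol-5-yl on the saturated chain carbon bound to a sulfur gives a 140-fold higher number from compound 1 to compound 4 (2.14 log units; beyond the scatter) and a 110-fold higher number from compound 2 to compound 4 (2.04 log units; beyond the scatter) as the two steps from the best-tolerated groups, so this place accepts far less than those two compounds suggested. The loss also does not stop at the level of the methylcarbamoyl group: the ring gives a 10-fold higher number from compound 3 to compound 4 (1.00 log units; beyond the scatter) on top of that. No measurement shown explains this loss.

Still open, from the compounds shown here alone, is how an amine or a carboxylic acid would read in place of the hydroxymethyl. Also open, going by these compounds, is whether a longer chain ending in a hydroxyl would keep the number of compound 1.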